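Amide chain extension from compound 2 in the series

The compounds below may be only part of what the source reports. "The series", "measured", "known", "first", "only" and "open" are said of these compounds alone.

Within the data shown here, compound 2 `CC(C)CNC(=O)n1c(=O)oc2cc(C3CCN(C)CC3)ccc21` is the reference point; in an assay on HEK293 cells for inhibition of acid ceramidase (Homo sapiens), read by fluorescence, with stated times of 10 min and 3 h (a lower number here means a stronger inhibitor, a higher number a weaker inhibitor), compound 2 gives 166 nM, the lowest of the three numbers so far. Compound 1 `CN1CCc2oc(=O)n(C(=O)NCCCCc3ccccc3)c2C1` carries a different core and a different amide chain, and compound 1 gives 516 nM. Among the measured compounds shown here, compound 3 `CC(C)CNC(=O)n1c(=O)oc2cc(C3CCCCN3C)ccc21` gives 1010 nM; the single measured step, a 6.1-fold higher number from compound 2 to compound 3 (0.78 log units; beyond the scatter), concerns only the saturated ring on the aromatic carbon and leaves the amide side untouched.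

Compound 4 `CN1CCC(c2ccc3c(c2)oc(=O)n3C(=O)NCCOCc2ccccc2)CC1` differs from compound 2 by (benzyloxy)methyl in place of isopropyl on a saturated chain carbon bound to an amide-type nitrogen. For the measured compounds named here, no measured step touches this part of the molecule, so the direction of the change has to be taken from the broad picture: compound 1 and compound 2, which differ in several places including the amide chain, still lie within a narrow band of one another. A larger amide substituent therefore seems tolerable rather than damaging, and a step of about a 1.3-fold lower number from compound 2 to compound 4 (0.11 log units; within the scatter) is expected, with no confident direction beyond the scatter. For compound 4 the estimate is 130 nM, in the range 40 nM to 400 nM.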

Compound 4, half-maximal inhibitory concentration: 215 nM
Compound 4: the middle estimate sits 1.7-fold (0.22 log units) below what was measured; measured number inside the range.
By their numbers in this assay, from the lowest: compounds 2 and 4 (each within the scatter of the next); then compounds 1 and 3 (each within the scatter of the next).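

In this assay the amide side proves open to substantial change: (benzyloxy)methyl in place of isopropyl on a saturated chain carbon bound to an amide-type nitrogen gives a 1.3-fold higher number from compound 2 to compound 4 (0.11 log units; within the scatter) and so no shift that can be told from the scatter. Among these compounds, this is the first single-place reading at this position, as the earlier step concerned only the saturated ring on the aromatic carbon. The longer 2-(benzyloxy)ethyl chain, with its added aromatic ring and ether oxygen, thus keeps compound 4 level with compound 2, and no supporting measurement bears on this result.

The ether oxygen and the aromatic ring enter together, so their separate contributions remain unresolved. Also open, on these data alone, is how this position responds to an amine or a carboxylic acid on the chain.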